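From methylimidazole to triazole on the shared core

The compounds below may be only part of what the source reports. "The series", "measured", "known", "first", "only" and "open" are said of these compounds alone.

In a physicochemical assay for solubility, in phosphate buffer, with a stated time of 18 h (on this read-out higher numbers stand for higher solubility and lower numbers for lower solubility), compound 1 (`CSc1nc(C(C)(C)C)nc2nc(N)c(C#N)c(N)c12`) gives 14000 nM and compound 3 (`Cc1c[nH]c(-c2nc(C(C)(C)C)nc3nc(N)c(C#N)c(N)c23)n1`) gives 5000 nM as the lower of these two numbers. The gap is a 2.8-fold lower number from compound 1 to compound 3 (0.45 log units; beyond the scatter) on this measure. Compound 2 (`CC(C)(C)c1nc(-c2ncc[nH]2)c2c(N)c(C#N)c(N)nc2n1`) shows < 1000 nM as a limit of the assay and not a number. The same swap without the methyl gave an at least 14-fold lower number from compound 1 to compound 2 (1.14 log units; beyond the scatter) in that case. Compound 4 (`CC(C)(C)c1nc(-c2ncn[nH]2)c2c(N)c(C#N)c(N)nc2n1`) brings one change: 1H-1,2,4-triazol-5-yl in place of 4-methyl-1H-imidazol-2-yl on an aromatic carbon on an aromatic carbon next to the ring nitrogen. Compound 2 lacks the methyl, as does compound 4, so an at least 5.0-fold higher number from compound 2 to compound 3 (0.69 log units; beyond the scatter) points to a fall. The expected move is a 2.5-fold lower number from compound 3 to compound 4 (0.40 log units; beyond the scatter) in this assay and no more than modest. Compound 4 is estimated at 2000 nM with an expected range from 700 nM to 6000 nM for now.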

Compound 4, solubility: 64500 nM
Estimate against measurement, compound 4: 32-fold (1.51 log units) below; measured number outside the range, above it.
By their numbers in this assay, from the lowest: compound 3; then compound 1; then compound 4. At a limit, below all of these: compound 2.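

In this assay, going by these compounds alone, the earlier compounds showed both imidazole groups at this position ending below methylsulfanyl, whereas 1H-1,2,4-triazol-5-yl reverses that order, with a 4.6-fold higher number from compound 1 to compound 4 (0.66 log units; beyond the scatter) and a 13-fold higher number from compound 3 to compound 4 (1.11 log units; beyond the scatter). The step from the unmethylated imidazole is larger still, an at least 64-fold higher number from compound 2 to compound 4 (1.80 log units; beyond the scatter). That step rests on a limit and not a number for compound 2: the limit of < 1000 nM in this assay, at which 1 of the 4 values shown sits.

The compounds shown leave open whether a methyl on the triazole ring would keep this higher number. They also leave open how an amine or a carboxylic acid at this position would read.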